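From phenyl to 4-methyl-2-nitrophenyl on sulfur

A few compounds are considered here, and "the series" means these few. Any claim that something is new, unique, unknown or untested is made for them only; others in the source may bear on it.

In a functional assay for inhibition, with Homo sapiens as the target (on this read-out lower numbers stand for tighter binding and higher numbers for weaker binding), compound 3 `CC(C)(Sc1ccccc1)C1OCC(C/C=C\CCC(=O)O)C(c2cccnc2)O1` gives 200 nM, within the scatter of compound 2 `CC(C)(Oc1ccccc1F)C1OCC(C/C=C\CCC(=O)O)C(c2cccnc2)O1` at 166 nM, while compound 1 `CC(C)(C)c1ccc(OC(C)(C)C2OCC(C/C=C\CCC(=O)O)C(c3cccnc3)O2)cc1` gives 1910 nM. Compound 4 `Cc1ccc(SC(C)(C)C2OCC(C/C=C\CCC(=O)O)C(c3cccnc3)O2)c([N+](=O)[O-])c1` carries 4-methyl-2-nitrophenyl in place of phenyl on a sulfur. Within the data shown here, three steps bear on this change. The data show a 1.2-fold higher number from compound 2 to compound 3 (0.08 log units; within the scatter), and the two large ones, a 12-fold lower number from compound 1 to compound 2 (1.06 log units; beyond the scatter) and a 9.6-fold lower number from compound 1 to compound 3 (0.98 log units; beyond the scatter), both lead away from the 4-(tert-butyl)phenyl group. Among the measured compounds shown here, no measured compound carries a nitro group or a 4-methyl group, so the evidence is indirect. The expected step is small and upward, a 1.3-fold higher number from compound 3 to compound 4 (0.11 log units; within the scatter), near the scatter. Compound 4 is estimated at 260 nM, with an expected range of 70 nM to 900 nM.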

Compound 4, dissociation constant: 158 nM
Compound 4: middle estimate off by 1.6-fold (0.22 log units), on the high side; low and high end bracket the measured number.
By their numbers in this assay, from the lowest: compounds 4, 2 and 3 (each within the scatter of the next); then compound 1.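

In this assay the sulfur position takes 4-methyl-2-nitrophenyl, with 10 heavy atoms against 6 for phenyl, with no change beyond the scatter (a 1.3-fold lower number from compound 3 to compound 4 (0.10 log units; within the scatter)). The 2-fluorophenoxy comparison also stays within the scatter (a 1.1-fold lower number from compound 2 to compound 4 (0.02 log units; within the scatter)), while the large gap from the 4-(tert-butyl)phenoxy compound holds (a 12-fold lower number from compound 1 to compound 4 (1.08 log units; beyond the scatter)). Nothing available accounts for this tolerance. The separate contributions of the methyl and the nitro group remain unresolved, as compound 4 carries both. Going by these compounds, whether an amine or a nitrile in place of the nitro group would keep this level also stays open.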